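Working notes: 3-fluorobenzyl to 4-methylbenzyl

The source may hold more compounds than are shown below. What is called first, only, known or untested is meant among the compounds shown, and "the series" means these compounds.

Measured in a functional assay on CCRF-CEM cells (Homo sapiens) for antiproliferative activity, with a stated time of 72 h; on this read-out higher numbers stand for weaker inhibition and lower numbers for stronger inhibition:
compound 1 `OC[C@H]1O[C@@H](n2cnc3c(NCc4cccc(F)c4)ncnc32)[C@H](O)[C@@H]1O` gives 4000 nM
compound 2 `OC[C@H]1O[C@@H](n2cnc3c(NCc4cccc(Br)c4)ncnc32)[C@H](O)[C@@H]1O` gives 5000 nM
compound 3 `OC[C@H]1O[C@@H](n2cnc3c(NCc4ccc(Br)cc4)ncnc32)[C@H](O)[C@@H]1O` gives 20600 nM

Compound 1 sits at the low end of these three numbers, level within the scatter with its nearest neighbour: a 1.3-fold higher number from compound 1 to compound 2 (0.10 log units; within the scatter). The furthest number is a clear distance away: a 5.2-fold higher number from compound 1 to compound 3 (0.71 log units; beyond the scatter).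

The next compound is compound 4 `Cc1ccc(CNc2ncnc3c2ncn3[C@@H]2O[C@H](CO)[C@@H](O)[C@H]2O)cc1`, still to be measured in this assay. The change is 4-methylphenyl in place of 3-fluorophenyl on a saturated chain carbon bound to a nitrogen on an aromatic ring.

The closest guide is compound 3, which carries 4-bromophenyl and shows two modest steps: a 5.2-fold higher number from compound 1 to compound 3 (0.71 log units; beyond the scatter), and a 4.1-fold higher number from compound 2 to compound 3 (0.61 log units; beyond the scatter). Among these three compounds, none goes against a higher number for the 4-substituted ring. The halogen swap adds little: a 1.3-fold higher number from compound 1 to compound 2 (0.10 log units; within the scatter). For the measured compounds named here, no compound with a methyl group has been measured, so carrying this over from bromo to methyl remains untested.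

A modest step towards a higher number is therefore expected: a 3.5-fold higher number from compound 1 to compound 4 (0.54 log units; beyond the scatter). The estimated value for compound 4 is 14000 nM. The expected range runs from 4500 nM to 40000 nM.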

Compound 4, half-maximal inhibitory concentration: > 166000 nM
Compound 4: only a limit was reported; the forecaster's own chance of this, stated with the estimate: 10%; at least 11-fold (1.07 log units) between middle value and limit.
By their numbers in this assay, from the lowest: compounds 1 and 2 (each within the scatter of the next); then compound 3. At a limit, above all of these: compound 4.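

In this assay compound 4 gives only a limit, not a number: the limit of > 166000 nM in this assay, at which 1 of the 4 values shown sits.

The group on the 4-substituted ring matters at this place, not just the ring pattern, since methyl in place of bromo gives an at least 8.0-fold higher number from compound 3 to compound 4 (0.90 log units; beyond the scatter), a wider step than the within-scatter halogen swap seen earlier, a 1.3-fold higher number from compound 1 to compound 2 (0.10 log units; within the scatter). Against the two lowest numbers in the series the change is large, with an at least 41-fold higher number from compound 1 to compound 4 (1.61 log units; beyond the scatter) and an at least 33-fold higher number from compound 2 to compound 4 (1.52 log units; beyond the scatter); these steps rest on a limit, so their true size is unknown.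

The compounds shown do not tell whether methyl itself accounts for the weak inhibition or whether the 4-methylphenyl group as a whole does, as no compound carries methyl on any other ring carbon. As far as these compounds go, how other groups in place of methyl on the 4-substituted ring would read, such as chloro, methoxy, an amine or a carboxylic acid, remains open.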